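A few compounds are considered here, and "the series" means these few. Any claim that something is new, unique, unknown or untested is made for them only; others in the source may bear on it.

Working notes on the series.

Three compounds of this set share one core and differ only in the aryl group on the carbon with a double bond to nitrogen. Compound 1 `O=C(CSc1nnc(-c2ccncc2)o1)N/N=C/c1ccc(Br)cc1` gives 169000 nM in an ADME assay on NIH3T3 cells (Mus musculus) for cytotoxicity, read by MTT assay, with a stated time of 24 h; on this read-out higher numbers stand for weaker inhibition and lower numbers for stronger inhibition. Compound 2 `O=C(CSc1nnc(-c2ccncc2)o1)N/N=C/c1cccc(F)c1` gives 205000 nM in this assay, and compound 3 `COc1cccc(/C=N/NC(=O)CSc2nnc(-c3ccncc3)o2)c1` gives 179000 nM in this assay. The steps among them are all small: a 1.2-fold higher number from compound 1 to compound 2 (0.08 log units; within the scatter), a 1.1-fold higher number from compound 1 to compound 3 (0.02 log units; within the scatter) and a 1.1-fold lower number from compound 2 to compound 3 (0.06 log units; within the scatter). Compound 3 therefore sits in the middle of a flat cluster, its number close to both neighbours.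

The next compound, compound 4 `O=C(CSc1nnc(-c2ccncc2)o1)N/N=C/c1cc(Cl)ccc1O`, differs from compound 3 by 5-chloro-2-hydroxyphenyl in place of 3-methoxyphenyl on a carbon with a double bond to nitrogen. Among the compounds with values here, none of the measured steps involves a hydroxy group, so the hydrogen-bond donor that enters has no precedent here; the only bearing steps are the three aryl swaps, each of which stayed within the scatter. On that basis the step expected in this assay is a 1.0-fold lower number from compound 3 to compound 4 (0.01 log units; within the scatter), none beyond the scatter. Compound 4 is estimated at 175000 nM, with a range from 90000 nM to 340000 nM.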

Compound 4, half-maximal inhibitory concentration: 166000 nM
Beside the measured number, compound 4's estimate is 1.1-fold (0.02 log units) above it, within the range that was stated.
By their numbers in this assay, from the lowest: compounds 4, 1, 3 and 2 (each within the scatter of the next).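

Within the data shown here, with 5-chloro-2-hydroxyphenyl on the carbon with a double bond to nitrogen, the only aryl group here carrying a hydrogen-bond donor, this assay gives a 1.1-fold lower number from compound 3 to compound 4 (0.03 log units; within the scatter), a 1.2-fold lower number from compound 2 to compound 4 (0.09 log units; within the scatter) and a 1.0-fold lower number from compound 1 to compound 4 (0.01 log units; within the scatter). The flat cluster therefore holds for a hydroxy-bearing, chlorinated aryl group as well as for the three earlier aryl groups, and compounds 1, 2, 3 and 4 do not separate at this position. Nothing measured on these compounds bears on why this position stays flat.

Going by these compounds, whether an aryl group bearing an amine or a carboxylic acid, or a longer alkyl chain in place of the aryl group, would give a step beyond the scatter remains open. On these data alone, the shared core is the same in all four compounds, so what a change there would do in this assay also remains open.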